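Branched chain on the core: compound 3 to compound 4

The source may hold more compounds than are shown below. What is called first, only, known or untested is meant among the compounds shown, and "the series" means these compounds.

Working notes on a set sharing one core. Compound 1 `CCn1c(=O)[nH]c(=O)c2[nH]c(-c3cnn(Cc4ccccc4)c3)nc21` has no result in an assay on CHO cells for displacement of a labelled ligand from adenosine receptor A1 (Homo sapiens); on this read-out lower numbers stand for stronger inhibition and higher numbers for weaker inhibition: its entry for compound 1 reads "not determined" (no result reported). Compound 2 `CCCn1c(=O)[nH]c2nc(-c3cnn(Cc4ccccc4)c3)[nH]c2c1=O` gives in this assay 1600 nM. Within the data shown here, compound 3 `CCCCn1c(=O)[nH]c2nc(-c3cnn(Cc4cccc(C(F)(F)F)c4)c3)[nH]c2c1=O` reaches only the limit of this assay, > 6000 nM, so no number stands for it; it is the one value among the three that sits at the limit of > 6000 nM in this assay, at which 1 of the 3 values shown sits. Compound 3 therefore stands at the weak end of the numbers shown, with the gap to compound 2 known only as reaching past the limit.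

The next entry, compound 4 `CC(C)Cn1c(=O)[nH]c2nc(-c3cnn(Cc4cccc(C(F)(F)F)c4)c3)[nH]c2c1=O`, differs from compound 3 by isopropyl in place of propyl on a saturated chain carbon bound to an aromatic nitrogen; cut one bond further out, the change reads butyl to isobutyl. Among the measured compounds shown here, no measured pair in this set shows such a change, so no step size can be drawn from data. With compound 3 already at the limit, no step beyond the scatter is expected in either direction, and the expected step from compound 3 to compound 4 is a step that the limit leaves unreadable from compound 3 to compound 4. Compound 4 is expected at 8000 nM, within a range from 3000 nM to 20000 nM, most likely again reported only as a limit.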

Compound 4, inhibition constant: > 6000 nM
Compound 4: only a limit was reported (the forecaster's own chance of this, stated with the estimate: 70%); the middle value does not contradict the limit.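

Compound 3 and compound 4 both end at a limit in this assay, so no step can be read between them: the limit of > 6000 nM in this assay, at which 2 of the 4 values shown sit.

The compounds shown leave open whether isobutyl in place of butyl on the shared core changes the result in this assay at all.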